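The source may hold more compounds than are shown below. What is called first, only, known or untested is meant among the compounds shown, and "the series" means these compounds.

In a functional assay on 518A2 cells (Homo sapiens) for cytotoxicity, read by MTT assay, with a stated time of 72 h (a lower number here means a stronger inhibitor, a higher number a weaker inhibitor), compound 1 `COc1ccc(-c2c(-c3cc(Br)c(OC)c(OC)c3)ncn2C)cc1F` gives 66 nM and compound 2 `COc1ccc(-c2c(-c3cc(N)c(OC)c(OC)c3)ncn2C)cc1O` gives 2800 nM as the higher of the two numbers, a gap beyond the scatter. Among the compounds with values here, compound 3 `COc1ccc(-c2c(-c3cc(N)c(OC)c(OC)c3)ncn2C)cc1F` differs from compound 2 by fluoro in place of hydroxy on an aromatic carbon, ortho to a methoxy group fluoro in place of hydroxy on an aromatic carbon as the only change. Within the data shown here, compound 1 also carries fluoro there and gives 66 nM but differs elsewhere too, so no measured step isolates this change. A moderate fall beyond the scatter is expected in this assay with a 4.7-fold lower number from compound 2 to compound 3 (0.67 log units; beyond the scatter) as the estimated step. For compound 3 the expected value is 600 nM within an estimated range of 120 nM to 3000 nM for now.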

Compound 3, half-maximal inhibitory concentration: > 10000 nM
Compound 3: a limit, no number; the forecaster's own chance of this, stated with the estimate: 3%; at least 16-fold (1.22 log units) between middle value and limit.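

In this assay compound 3 stands as a limit and not a number: the limit of > 10000 nM in this assay, at which 1 of the 3 values shown sits.

With the amino group held constant, hydroxy ortho to a methoxy group outperforms fluoro, with an at least 3.5-fold higher number from compound 2 to compound 3 (0.55 log units; beyond the scatter). With fluoro held constant, replacing bromo with amino gives an at least 150-fold higher number from compound 1 to compound 3 (2.18 log units; beyond the scatter), so fluoro at this position does not by itself set the activity level.

Still open, as far as these compounds go, is whether hydroxy would also outperform fluoro in a compound carrying bromo. Also open, from the compounds shown here alone, is whether a chloro or methyl group in place of bromo would retain activity.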